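The compounds below may be only part of what the source reports. "The series", "measured", "known", "first", "only" and "open" are said of these compounds alone.

Three compounds sharing one core were measured in a functional assay on PC-3 cells (Homo sapiens) for cytotoxicity, read by MTT assay, with a stated time of 72 h; a lower number here means a stronger inhibitor, a higher number a weaker inhibitor. Compound 1 `CCCCCCNc1nc(SCc2ccc(C(F)(F)F)cc2)nc2ccccc12` gives 19000 nM, compound 2 `FC(F)(F)c1ccc(CSc2nc(N3CCCCC3)c3ccccc3n2)cc1` gives 25500 nM, and compound 3 `FC(F)(F)c1ccc(CSc2nc(Nc3cccc(Cl)c3)c3ccccc3n2)cc1` gives 13400 nM. Compound 3 holds the smallest of the three numbers, but the steps of a 1.4-fold lower number from compound 1 to compound 3 (0.15 log units; within the scatter) and a 1.9-fold lower number from compound 2 to compound 3 (0.28 log units; within the scatter) both lie within the scatter, as does a 1.3-fold higher number from compound 1 to compound 2 (0.13 log units; within the scatter), so the three are not separated. Compound 4 `O=[N+]([O-])c1ccc(Nc2nc(SCc3ccc(C(F)(F)F)cc3)nc3ccccc23)cc1` differs from compound 3 by 4-nitrophenyl in place of 3-chlorophenyl on a nitrogen on an aromatic ring. The steps that touch the same nitrogen, from compound 1 and from compound 2 to compound 3, were each within the scatter, so no change beyond the scatter is expected here either. For compound 4 the expected step is a 1.0-fold lower number from compound 3 to compound 4 (0.01 log units; within the scatter), giving an estimate of 13000 nM in this assay, within 5000 nM to 35000 nM.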

Compound 4, half-maximal inhibitory concentration: 7900 nM
For compound 4 the middle estimate is 1.6-fold (0.22 log units) above the measured one; measured number inside the range.
By their numbers in this assay, from the lowest: compounds 4, 3, 1 and 2 (each within the scatter of the next, the first and the last beyond it).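

Going by these compounds alone, with 4-nitrophenyl on the nitrogen, the compounds show steps beyond the scatter at this position for the first time, both modest: a 3.2-fold lower number from compound 2 to compound 4 (0.51 log units; beyond the scatter) and a 2.4-fold lower number from compound 1 to compound 4 (0.38 log units; beyond the scatter). Against 3-chlorophenyl, however, the change stays within the scatter, at a 1.7-fold lower number from compound 3 to compound 4 (0.23 log units; within the scatter), so these two aryl groups are not separated. No measurement at hand accounts for these steps. Open, on these data alone, is whether the nitro group itself matters, or whether a ring carrying a nitrile, an amine or a carboxylic acid would read the same. Also open, as far as these compounds go, is how 3-nitrophenyl would compare with 4-nitrophenyl.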